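The compounds below may be only part of what the source reports. "The series", "measured", "known", "first", "only" and "open" are said of these compounds alone.

Measured compounds:
Compound 1, `Cc1cc(C2CCC2)c(S(C)(=O)=O)cc1C(=O)N=C(N)N` — 8.2 nM
Compound 2, `Cc1cc(C2CCCCC2)c(S(C)(=O)=O)cc1C(=O)N=C(N)N` — 22 nM
Compound 3, `Cc1cc(Sc2ccccc2Cl)c(S(C)(=O)=O)cc1C(=O)N=C(N)N` — 14 nM

In a functional assay for inhibition of sodium/hydrogen exchanger (Oryctolagus cuniculus) (on this read-out lower numbers stand for stronger inhibition and higher numbers for weaker inhibition), compound 3 gives 14 nM. Its number lies between those of compound 1 and compound 2, and neither gap is beyond the usual scatter: a 1.7-fold higher number from compound 1 to compound 3 (0.23 log units; within the scatter), and a 1.6-fold lower number from compound 2 to compound 3 (0.20 log units; within the scatter). Among the compounds with values here, the one step among the three that does exceed the scatter is a 2.7-fold higher number from compound 1 to compound 2 (0.43 log units; beyond the scatter).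

Compound 4, `Cc1cc(OC2CCCCC2)c(S(C)(=O)=O)cc1C(=O)N=C(N)N`, has not yet been measured. Compared with compound 3, the change is cyclohexyloxy in place of (2-chlorophenyl)sulfanyl on an aromatic carbon. The ring that enters is the same six-membered non-aromatic ring of carbon that compound 2 carries directly on the aromatic carbon, so the step from compound 2 to compound 3 is the closest guide, and it was within the scatter. The step from compound 1 to compound 2 shows that a larger ring at this position can raise the number modestly. Taken together, compound 4 is expected to land near compound 2 and compound 3, with a step of a 1.4-fold higher number from compound 3 to compound 4 (0.15 log units; within the scatter) that is not expected to exceed the scatter. Compound 4 is therefore estimated at 20 nM in this assay, with a likely range from 8 nM to 50 nM.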

Compound 4, half-maximal inhibitory concentration: 37 nM
The estimate for compound 4 lay 1.9-fold (0.27 log units) below the measured number, within the range that was stated.
By their numbers in this assay, from the lowest: compounds 1, 3, 2 and 4 (each within the scatter of the next, the first and the last beyond it).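

In this assay, cyclohexyloxy in place of (2-chlorophenyl)sulfanyl (a 2.6-fold higher number from compound 3 to compound 4 (0.42 log units; beyond the scatter)) is a step that leaves the scatter, whereas the earlier exchange of cyclohexyl for (2-chlorophenyl)sulfanyl (a 1.6-fold lower number from compound 2 to compound 3 (0.20 log units; within the scatter)) stayed inside it, so the group on this aromatic carbon, ortho to the methylsulfonyl group, can separate two compounds that both carry a single six-membered ring. Setting the same non-aromatic ring on this carbon through an oxygen, with cyclohexyloxy in place of cyclohexyl (a 1.7-fold higher number from compound 2 to compound 4 (0.23 log units; within the scatter)), gives no change that can be told from the scatter, while cyclohexyloxy in place of cyclobutyl (a 4.5-fold higher number from compound 1 to compound 4 (0.65 log units; beyond the scatter)) opens the widest gap seen so far at this position. Nothing given here accounts for these differences, and the numbers alone offer no cause for them.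

The compounds shown leave open whether the smaller ring would keep its place if linked through oxygen, as cyclobutyloxy, since no compound pairs the two ring sizes on that link. They also leave open how a cyclohexylamino group, a cyclohexylsulfanyl group or an unsubstituted phenoxy group would compare at this carbon.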